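The source may report more compounds than this note shows. Statements on the series, on what has been measured and on what is new or still open speak of the compounds shown alone.

Compound 1 `Fc1cc(F)cc(CN2CCN=C2S)c1` gives 1400 nM in an assay on isolated protein for inhibition of Dopamine beta-hydroxylase (Bos taurus); a higher number here means a weaker inhibitor, a lower number a stronger inhibitor.
Compound 2 `Sc1ncnn1Cc1ccccc1` gives 75000 nM in this assay.

Of the two measured compounds, compound 2 has the higher number, and the gap to compound 1 lies well beyond the usual scatter. Compound 3 `Fc1cccc(Cn2ncnc2S)c1` differs from compound 2 in one place: fluoro in place of hydrogen on an aromatic carbon. For the measured compounds named here, no measured pair shows what such a change alone does to this assay, so only a modest step is expected, if any beyond the scatter, and most plausibly toward a somewhat lower number. The step from compound 2 to compound 3 is expected to be a 1.5-fold lower number from compound 2 to compound 3 (0.18 log units; within the scatter). Compound 3 is therefore estimated at 50000 nM, within a range from 15000 nM to 150000 nM.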

Compound 3, half-maximal inhibitory concentration: 15000 nM
Compound 3: the middle estimate sits 3.3-fold (0.52 log units) above what was measured; the measured number falls inside the stated range.
By their numbers in this assay, from the lowest: compound 1; then compound 3; then compound 2.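

The change of fluoro in place of hydrogen on an aromatic carbon, meta to a group of 7 heavy atoms, gives a 5.0-fold lower number from compound 2 to compound 3 (0.70 log units; beyond the scatter). For the compounds shown here, this is the first single-place comparison in this assay, and it shows that this position on the six-membered aromatic ring responds to the addition of one fluorine atom. No measurement shown gives a cause for this step. On these data alone, whether a larger group, such as chloro or methoxy, would have a similar effect at this place remains open. So does the effect of fluoro elsewhere on this ring.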